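Compound 3: a cyclopropyl swap on a weak series

This account rests on a few compounds, and the source may have more. Where it says the series, first, only, none or still open, it means among the compounds named here.

Compound 1 `CCC#C[C@@]1(O)[C@@H](CO)O[C@@H](n2ccc(=O)[nH]c2=O)[C@@H]1O`: 338000 nM
Compound 2 `CCC[C@@]1(O)[C@@H](CO)O[C@@H](n2ccc(=O)[nH]c2=O)[C@@H]1O`: > 350000 nM (a limit, not a number)

In a functional assay on L1210 cells (Mus musculus), read by MTT assay (a lower number here means a stronger inhibitor, a higher number a weaker inhibitor), compound 2 gives > 350000 nM, which is a limit of the assay and not a number. Compound 3 `O=c1ccn([C@@H]2O[C@H](CO)[C@](O)(C3CC3)[C@H]2O)c(=O)[nH]1` differs from it by one change: cyclopropyl in place of propyl on a saturated ring carbon. Among the compounds with values here, the only measured step bearing on this is an at least 1.0-fold higher number from compound 1 to compound 2 (0.01 log units; that floor lies within the scatter), where propyl replaces but-1-yn-1-yl, and it stays within the scatter. On that single step, no change beyond the scatter is expected in this assay. The estimated step is a number no higher from compound 2 to compound 3 (the limit leaves the size open). Compound 3 is expected at about 350000 nM, with an estimated range from 150000 nM to 700000 nM.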

Compound 3, half-maximal inhibitory concentration: > 350000 nM
Compound 3: no number, only a limit (the forecaster's own chance of this, stated with the estimate: 70%); the middle value lies on the limit itself.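

With cyclopropyl, a group carrying a ring now sits at this position alongside the two open chains, and in this assay replacing but-1-yn-1-yl with it gives an at least 1.0-fold higher number from compound 1 to compound 3 (0.01 log units; that floor lies within the scatter). The step between compound 2 and compound 3 cannot be read. So neither an open chain nor this small ring brings a measurable gain in strength here, and differences among these groups stay hidden at the edge of the assay's range: the limit of > 350000 nM in this assay, at which 2 of the 3 values shown sit.

From the compounds shown here alone, whether an amine or a carboxylic acid at this position would give a clearly lower number remains open. So does the effect of a longer chain.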